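The source may hold more compounds than are shown below. What is called first, only, known or untested is meant among the compounds shown, and "the series" means these compounds.

Compound 1 `C=C1CC[C@@H]2[C@](C)(CNCc3cccc(OC)c3)[C@H](O)CC[C@@]2(C)[C@@H]1/C=C/C1=CCOC1=O`: 780 nM in a functional assay on BMMC cells (Mus musculus, strain C57BL/6) for inhibition, with stated times of 5 days and 48 h; a lower number here means a stronger inhibitor, a higher number a weaker inhibitor.
Compound 2 `C=C1CC[C@@H]2[C@](C)(CNCc3ccc(OC)c(OC)c3)[C@H](O)CC[C@@]2(C)[C@@H]1/C=C/C1=CCOC1=O`: 3740 nM.

Compound 2 gives the higher of these two numbers, so it is the weaker inhibitor of the pair. Compound 3 `C=C1CC[C@@H]2[C@](C)(CNCc3ccc(F)cc3)[C@H](O)CC[C@@]2(C)[C@@H]1/C=C/C1=CCOC1=O` carries 4-fluorophenyl in place of 3,4-dimethoxyphenyl on a saturated chain carbon bound to an amine nitrogen. Among the compounds with values here, one measured step bears on this change: a 4.8-fold higher number from compound 1 to compound 2 (0.68 log units; beyond the scatter). As far as these compounds go, compound 3 no longer carries the 3,4-dimethoxyphenyl, so its number is expected to fall back toward that of compound 1, while the effect of the entering 4-fluorophenyl is untested here. The expected step is a 4.2-fold lower number from compound 2 to compound 3 (0.62 log units; beyond the scatter). Compound 3 is therefore estimated at 900 nM, within a range of 300 nM to 3000 nM.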

Compound 3, half-maximal inhibitory concentration: 350 nM
For compound 3 the middle estimate is 2.6-fold (0.41 log units) above the measured one; the measured number falls inside the stated range.
By their numbers in this assay, from the lowest: compound 3; then compound 1; then compound 2.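

In this assay, the ring on this saturated chain carbon bound to an amine nitrogen needs no methoxy group for inhibition: 4-fluorophenyl in place of 3,4-dimethoxyphenyl gives an 11-fold lower number from compound 2 to compound 3 (1.03 log units; beyond the scatter). It also improves on the single-methoxy ring, with a 2.2-fold lower number from compound 1 to compound 3 (0.35 log units; beyond the scatter). Nothing measured here explains these shifts.

The compounds shown leave open whether the fluorine itself helps or whether removing the methoxy groups is enough. A plain phenyl ring would separate those two readings, and a pyridine ring would show whether the ring must be carbon only.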